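Working notes: step from compound 1 to compound 3

The source may hold more compounds than are shown below. What is called first, only, known or untested is meant among the compounds shown, and "the series" means these compounds.

Measured so far:
compound 1 `Cc1cc(O)c(C2=NN(c3ccc(S(N)(=O)=O)cc3)C(c3ccccc3O)C2)cc1Cl` gives 26900 nM in a functional assay on U-251 cells (Homo sapiens) for antiproliferative activity, with a stated time of 48 h; on this read-out lower numbers stand for higher toxicity in this test and higher numbers for lower toxicity in this test
compound 2 `Cc1cc(O)c(C2=NN(c3ccc(S(N)(=O)=O)cc3)C(c3ccccc3Cl)C2)cc1Cl` gives 36900 nM in this assay

Compound 1 has the lowest of the two numbers; its nearest neighbour is compound 2, and the step of a 1.4-fold higher number from compound 1 to compound 2 (0.14 log units; within the scatter) is the only measured one. It concerns the same saturated ring carbon, but only exchanges one small group there.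

Compound 3 `COc1ccc(C2CC(c3cc(Cl)c(C)cc3O)=NN2c2ccc(S(N)(=O)=O)cc2)c(OC)c1OC` differs from compound 1 by 2,3,4-trimethoxyphenyl in place of 2-hydroxyphenyl on a saturated ring carbon. Going by the values given here, no measured step covers a change of this kind; the one step on that position stayed within the scatter, which gives no reason to expect a large move in this assay, but the enlarged group leaves the direction open. Compound 3 is therefore expected to land close to compound 1, at an estimated 22000 nM with a range from 6000 nM to 80000 nM. The expected step is a 1.2-fold lower number from compound 1 to compound 3 (0.09 log units; within the scatter).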

Compound 3, concentration lethal to 50% of the cells: 29700 nM
Estimate against measurement, compound 3: 1.4-fold (0.13 log units) below; the range from low to high includes it.
By their numbers in this assay, from the lowest: compounds 1, 3 and 2 (each within the scatter of the next).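

In this assay, the saturated ring carbon next to the ring nitrogen accepts 2,3,4-trimethoxyphenyl without a step beyond the scatter: a 1.1-fold higher number from compound 1 to compound 3 (0.04 log units; within the scatter), and a 1.2-fold lower number from compound 2 to compound 3 (0.09 log units; within the scatter). The earlier compounds shown here showed only an exchange of one small group on this aryl ring, whereas here the whole group is replaced, with 0 hydrogen-bond donors and 3 hydrogen-bond acceptors entering in place of 1 of each, and the number still does not move beyond the scatter. No evidence is at hand that explains this result.

On these data alone, all three compounds keep an aromatic ring on this carbon, so a piperidine or a carboxylic acid on a short alkyl chain there remains untested in these data. Changes to the 4-sulfamoylphenyl and 5-chloro-2-hydroxy-4-methylphenyl groups, shared by all three compounds, also remain open.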